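Removing One Methoxy Group: An Expectation for Compound 4

The compounds below may be only part of what the source reports. "The series", "measured", "known", "first", "only" and "open" are said of these compounds alone.

Of the compounds shown here, three sharing one core have been tested in a functional assay on A549 cells (Homo sapiens) for inhibition, read by colorimetric assay and MTT assay, with a stated time of 72 h; a higher number here means a weaker inhibitor, a lower number a stronger inhibitor. Compound 1 `COc1cc(C(=O)NNC(=S)Nc2csc(-c3ccccc3)c2)cc(OC)c1OC` gives 39000 nM. Compound 2 `COc1cc(C(=O)NNC(=S)Nc2csc(-c3ccc(C)cc3)c2)cc(OC)c1OC` gives 39000 nM, and the step of no change at the digits printed from compound 1 to compound 2 (within the scatter). Compound 3 `COc1cc(OC)cc(C(=O)NNC(=S)Nc2csc(-c3ccc(C)cc3)c2)c1` gives 32000 nM, and the step of a 1.2-fold lower number from compound 2 to compound 3 (0.09 log units; within the scatter). Compound 2 therefore stands level with compound 1 at the digits shown, the two together the highest numbers of the three, with compound 3 the furthest away; yet all three lie within the scatter of one another, so none can be called the stronger or the weaker inhibitor.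

Compound 4 `COc1ccc(C(=O)NNC(=S)Nc2csc(-c3ccc(C)cc3)c2)cc1OC` has not yet been measured. It differs from compound 2 in one place: hydrogen in place of methoxy on an aromatic carbon. The measured step that bears most directly on this change is a 1.2-fold lower number from compound 2 to compound 3 (0.09 log units; within the scatter), in which a methoxy group was also removed and the number stayed within the scatter. The methyl step no change at the digits printed from compound 1 to compound 2 (within the scatter) likewise left the number unchanged. On this basis compound 4 is expected to give a number close to that of compound 2, with no step beyond the scatter. The expected step is a 1.1-fold lower number from compound 2 to compound 4 (0.03 log units; within the scatter). The estimate for compound 4 in this assay is 36000 nM, with a range from 15000 nM to 85000 nM.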

Compound 4, half-maximal inhibitory concentration: 36000 nM
Compound 4: middle estimate and measured number agree at the digits printed; the range from low to high includes it.
By their numbers in this assay, from the lowest: compounds 3, 4, 1 and 2 (each within the scatter of the next).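

In this assay, the methoxy group that sits ortho to a methoxy group, meta to a methoxy group and meta to a large group can give way to hydrogen with a 1.1-fold lower number from compound 2 to compound 4 (0.03 log units; within the scatter) and nothing more. Compound 3 had shown the same for one other methoxy group on this ring, with a 1.2-fold lower number from compound 2 to compound 3 (0.09 log units; within the scatter), and compound 4 now adds a second place on that ring where losing a single methoxy group leaves the number within the scatter of compound 2. No measurement available here explains why these numbers hold together, so the result can be described but not accounted for.

For the compounds shown here, whether this carbon tolerates anything at all remains open, since hydrogen and methoxy are the only groups seen there; a hydroxyl group, an amine or a carboxylic acid in the same place might or might not move the number beyond the scatter. Also open, as far as these compounds go, is what happens to the number when two methoxy groups, or all three, are replaced by hydrogen on the same ring.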